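Amide in place of urea on a shared quinazoline-type core

A few compounds are considered here, and "the series" means these few. Any claim that something is new, unique, unknown or untested is made for them only; others in the source may bear on it.

Measured so far:
Compound 1, `COc1cc(Nc2ncnc3c(NC(=O)Nc4cccc(Oc5ccccc5)c4)cccc23)cc(OC)c1`: 14000 nM
Compound 2, `COc1cc(Nc2ncnc3c(NC(=O)Nc4ccc(Cl)c(C(F)(F)F)c4)cccc23)cc(OC)c1`: > 20000 nM
Compound 3, `COc1cc(Nc2ncnc3c(NC(=O)Nc4cc(C(F)(F)F)cc(C(F)(F)F)c4)cccc23)cc(OC)c1`: 467 nM

Three compounds share one core and differ only in the group carried on the urea. In a functional assay on RT-112 cells (Homo sapiens) for antiproliferative activity, read by MTT assay, with a stated time of 72 h (on this read-out lower numbers stand for stronger inhibition of growth and higher numbers for weaker inhibition of growth), compound 3 gives 467 nM and compound 1 gives 14000 nM. Compound 2 is reported only as a limit, > 20000 nM, so its true value is not known; this is the limit of > 20000 nM in this assay, at which 1 of the 3 values shown sits, and compound 2 sits at the weak end of the three values shown.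

Compound 4, `COc1cc(Nc2ncnc3c(NC(=O)c4ccc(CN(C)C)cc4)cccc23)cc(OC)c1`, has not yet been measured. It differs from compound 2 in one place: 4-((dimethylamino)methyl)phenyl in place of (4-chloro-3-(trifluoromethyl)phenyl)amino on a carbonyl carbon. Since compound 2 shows only a limit, the step from it can be read in one direction at most, and it is expected that the step of an at least 4.0-fold lower number from compound 2 to compound 4 (0.60 log units; beyond the scatter) points toward stronger inhibition, though its size is uncertain. Compound 4 is therefore expected to give about 5000 nM in this assay, within a range from 500 nM to 20000 nM.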

Compound 4, concentration for 50% growth inhibition: 4370 nM
Compound 4: the middle estimate sits 1.1-fold (0.06 log units) above what was measured; low and high end bracket the measured number.
By their numbers in this assay, from the lowest: compound 3; then compound 4; then compound 1. At a limit, above all of these: compound 2.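

In this assay, compound 4 carries 4-((dimethylamino)methyl)phenyl directly on the carbonyl carbon, so this position is now seen as an amide rather than a urea. The change gives an at least 4.5-fold lower number from compound 2 to compound 4 (0.66 log units; beyond the scatter), which shows that growth inhibition at this carbonyl carbon can be measured without the urea nitrogen and its (4-chloro-3-(trifluoromethyl)phenyl) group. From the compounds shown here alone, the true size of the step remains unknown, since compound 2 is reported only as a limit: the limit of > 20000 nM in this assay, at which 1 of the 4 values shown sits.

The compounds shown leave open whether the loss of the urea or the arrival of the dimethylaminomethyl group accounts for the step, as both change together here. A urea carrying 4-((dimethylamino)methyl)phenyl, or an amide with morpholine in place of the dimethylamino group, would bear on that question.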